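The source may report more compounds than this note shows. Statements on the series, on what has been measured and on what is new or still open speak of the compounds shown alone.

Measured in an assay on isolated protein for inhibition of alkaline phosphatase, tissue-nonspecific isozyme (Homo sapiens); on this read-out lower numbers stand for stronger inhibition and higher numbers for weaker inhibition:
compound 1, `COc1ccc(C#N)cc1S(=O)(=O)Nc1cnc2ccccc2c1`: 38 nM
compound 2, `COc1ccc(C(F)(F)F)cc1S(=O)(=O)Nc1cnc2ccccc2c1`: 26 nM

Compound 2 gives the lower of the two numbers, but the gap to compound 1 is within the scatter. Compound 3, `COc1ccc(Cl)cc1S(=O)(=O)Nc1cnc2ccccc2c1`, is still to be measured; it differs from compound 2 by chloro in place of trifluoromethyl on an aromatic carbon. For the measured compounds named here, the only step bearing on this exchange is the earlier swap at the same place, a 1.5-fold lower number from compound 1 to compound 2 (0.16 log units; within the scatter), which did not move the number beyond the scatter. A similar outcome is therefore expected here, namely a 1.3-fold higher number from compound 2 to compound 3 (0.13 log units; within the scatter), with no clear direction. The estimate for compound 3 is 35 nM, with a range of 15 nM to 90 nM.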

Compound 3, half-maximal inhibitory concentration: 6 nM
Compound 3: the middle estimate sits 5.8-fold (0.77 log units) above what was measured, and the stated range ends above it.
By their numbers in this assay, from the lowest: compound 3; then compounds 2 and 1 (each within the scatter of the next).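

In this assay, this position para to a methoxy group turns out to respond to the choice of substituent: chloro gives a 4.3-fold lower number from compound 2 to compound 3 (0.64 log units; beyond the scatter) and a 6.3-fold lower number from compound 1 to compound 3 (0.80 log units; beyond the scatter), whereas trifluoromethyl in place of nitrile had stayed within the scatter. No measurement shown here explains the gain from chloro. The compounds shown leave open whether the gain is particular to chloro, which bromo, methyl or an amine at this place could test. As far as these compounds go, whether the gain persists with another group in place of the methoxy group also remains open.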